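Pyridin-2-yl for 2-ethoxyphenyl: Notes on Compound 3

The source may hold more compounds than are shown below. What is called first, only, known or untested is meant among the compounds shown, and "the series" means these compounds.

Measured so far:
compound 1 `Cc1ccccc1Nc1nc2nonc2nc1Nc1ccccc1F`: 1100 nM
compound 2 `CCOc1ccccc1Nc1nc2nonc2nc1Nc1ccccc1F`: 5600 nM

In an assay on mitochondria from L6 cells (Rattus norvegicus) for activation, with a stated time of 90 min (a lower number here means that less compound is needed, a higher number that more compound is needed for the effect), compound 2 gives the highest of the two numbers, compound 1 being the nearest, as shown by a 5.1-fold higher number from compound 1 to compound 2 (0.71 log units; beyond the scatter). Compound 3 `Fc1ccccc1Nc1nc2nonc2nc1Nc1ccccn1` differs from compound 2 in one place: pyridin-2-yl in place of 2-ethoxyphenyl on a nitrogen on an aromatic ring. Among the compounds with values here, the only measured step bearing on this is the one just named, in which ethoxy in place of methyl on an aromatic carbon raised the number. Since the 2-ethoxyphenyl leaves in compound 3, the number is expected to fall back toward compound 1, an expected step of a 3.7-fold lower number from compound 2 to compound 3 (0.57 log units; beyond the scatter). Compound 3 is estimated at 1500 nM, in the range 400 nM to 6000 nM.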

Compound 3, half-maximal effective concentration: 9000 nM
Estimate against measurement, compound 3: 6.0-fold (0.78 log units) below, outside the stated range (above it).
By their numbers in this assay, from the lowest: compound 1; then compounds 2 and 3 (each within the scatter of the next).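

In this assay pyridin-2-yl and 2-ethoxyphenyl on this nitrogen cannot be told apart (a 1.6-fold higher number from compound 2 to compound 3 (0.21 log units; within the scatter)), so removing the 2-ethoxyphenyl does not by itself return the number to that of compound 1. Set against the 2-methylphenyl, the pyridin-2-yl gives a clear rise (an 8.2-fold higher number from compound 1 to compound 3 (0.91 log units; beyond the scatter)), leaving compound 1 alone with the lower number among the three. Nothing available explains this result.

From the compounds shown here alone, whether that lower number rests on the methyl group or on the carbon-only ring remains open. An unsubstituted phenyl or a methyl-bearing pyridine on this nitrogen would separate the two.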